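Methyl on the fused ring: compound 4 from compound 2

A few compounds are considered here, and "the series" means these few. Any claim that something is new, unique, unknown or untested is made for them only; others in the source may bear on it.

Compound 1, `CC(=O)Nc1nc2ccccn2c1-c1ccc(O)cc1`; in an assay on isolated protein for inhibition of ubiquitin carboxyl-terminal hydrolase 14 (Homo sapiens) (a higher number here means a weaker inhibitor, a lower number a stronger inhibitor), compound 1 gives > 100000 nM, a limit of the assay.
Compound 2, `Nc1nc2ccccn2c1-c1ccc(O)cc1`; in this assay compound 2 gives > 100000 nM, a limit of the assay.
Compound 3, `CC(C)Nc1nc2ccccn2c1-c1ccc(O)cc1`; in this assay compound 3 gives > 100000 nM, a limit of the assay.

Compound 2 therefore stands at the limit, together with every other measured compound; the limit of > 100000 nM in this assay, at which 3 of the 3 values shown sit, describes this. Compound 4, `Cc1ccc2nc(N)c(-c3ccc(O)cc3)n2c1`, differs from compound 2 in one place: methyl in place of hydrogen on an aromatic carbon. The measured steps change only the nitrogen substituent: a step that the two limits leave unreadable from compound 1 to compound 2, a step that the two limits leave unreadable from compound 1 to compound 3 and a step that the two limits leave unreadable from compound 2 to compound 3 are all steps the two limits leave unreadable, so none of them bears readably on a methyl entering the fused ring. With no readable step in hand, compound 4 is expected to remain near the limit, the step of a number no higher from compound 2 to compound 4 (the limit leaves the size open) being an expectation of no change beyond the scatter. Compound 4 is estimated at 100000 nM in this assay, within 30000 nM to 300000 nM, most likely reported again only as a limit.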

Compound 4, half-maximal inhibitory concentration: > 100000 nM
Compound 4: a limit, no number; the forecaster's own chance of this, stated with the estimate: 85%; the middle value lies on the limit itself.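

Compound 2 and compound 4 are both reported only as limits, so the step between them cannot be read: the limit of > 100000 nM in this assay, at which 4 of the 4 values shown sit.
The compounds shown leave open whether any change to the shared core brings a measurable value in this assay, and how far the methyl or any nitrogen substituent matters.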